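This account rests on a few compounds, and the source may have more. Where it says the series, first, only, none or still open, it means among the compounds named here.

Three thiosemicarbazones of the shared core have been read in a toxicity assay on THP-1 cells (Homo sapiens) for cytotoxicity, read by MTT assay, with a stated time of 72 h; on this read-out higher numbers stand for an effect only at larger amounts of compound and lower numbers for an effect already at smaller amounts. Compound 1 `Cn1cc(/C=N/NC(N)=S)c2ccccc21` reaches only a limit there, > 200000 nM. Compound 2 `COc1ccc(/C=N/NC(N)=S)c2ccccc12` gives 47000 nM. Compound 3 `CCCCOc1c(/C=N/NC(N)=S)ccc2ccccc12` likewise returns a limit, > 200000 nM, and so stands among the numbers shown without a number of its own, at the limit of > 200000 nM in this assay, at which 2 of the 3 values shown sit. Compound 4 `COCOc1c(/C=N/NC(N)=S)ccc2ccccc12` differs from compound 3 by methoxy in place of propyl on a saturated chain carbon bound to an oxygen on an aromatic ring. Among the compounds with values here, no step between measured compounds covers this change, and no step beyond the scatter is expected, so the step from compound 3 to compound 4 is estimated at a number no higher from compound 3 to compound 4 (the limit leaves the size open). Compound 4 is expected in this assay at 200000 nM, within 60000 nM to 400000 nM, most likely again only as a limit.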

Compound 4, half-maximal effective concentration: 56000 nM
Estimate against measurement, compound 4: 3.6-fold (0.55 log units) above; measured number outside the range, below it.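

In this assay, the change from butoxy to methoxymethoxy goes with an at least 3.5-fold lower number from compound 3 to compound 4 (0.55 log units; beyond the scatter). Within the data shown here, this is the first step read, and it shows that the read-out responds to the group on this oxygen on an aromatic ring. The full size of the step stays open because compound 3 holds only a limit: the limit of > 200000 nM in this assay, at which 2 of the 4 values shown sit.

As far as these compounds go, whether the change follows the oxygen in the chain or the chain length remains open. Also open, from the compounds shown here alone, is how a longer chain or an amine at this place would read.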